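The source may hold more compounds than are shown below. What is called first, only, known or untested is meant among the compounds shown, and "the series" means these compounds.

Measured so far in an assay on A7R5 cells for displacement of a labelled ligand from Endothelin-1 receptor (Rattus norvegicus); a lower number here means a stronger inhibitor, a higher number a weaker inhibitor:
Compound 1: `COc1cccc(Sc2c(NS(=O)(=O)c3ccc(C(C)(C)C)cc3)noc2CCC/C=N/O)c1` gives 1500 nM
Compound 2: `COc1cccc(Sc2c(NS(=O)(=O)c3ccc(C(C)(C)C)cc3)noc2CCC=O)c1` gives 380 nM

Compound 2 stands with the lowest number of the two, and compound 1 sits at the far end: a 3.9-fold lower number from compound 1 to compound 2 (0.60 log units; beyond the scatter). That step is the only one measured, and it exchanged the end of the same chain on the shared core.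

Compound 3, `COc1cccc(Sc2c(NS(=O)(=O)c3ccc(C(C)(C)C)cc3)noc2CCCC(N)=O)c1`, has not yet been measured. It differs from compound 2 by carbamoylmethyl in place of formyl on a saturated chain carbon, two bonds along the chain from an aromatic carbon. Going by the values given here, the one measured step bears on it only loosely: from compound 1 to compound 2 the chain end was cut back and the number fell, whereas the change to compound 3 lengthens the chain end again, though with a different group entering. Among the compounds with values here, on that slender basis a modest rise in the number is expected in this assay, with wide uncertainty, because a 3.9-fold lower number from compound 1 to compound 2 (0.60 log units; beyond the scatter) is the only guide and the entering group is not the one that left there.

The expected step is a 2.4-fold higher number from compound 2 to compound 3 (0.37 log units; beyond the scatter). Compound 3 is therefore estimated at 900 nM, within a range from 250 nM to 3000 nM.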

Compound 3, half-maximal inhibitory concentration: 6300 nM
The estimate for compound 3 lay 7.0-fold (0.85 log units) below the measured number; the whole stated range lies below it.
By their numbers in this assay, from the lowest: compound 2; then compound 1; then compound 3.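

In this assay, replacing the formyl group at this position with carbamoylmethyl costs far more than the earlier change at the chain end suggested (a 17-fold higher number from compound 2 to compound 3 (1.22 log units; beyond the scatter)), a large step that leaves compound 2 well ahead. Compound 3 also stands apart from compound 1 (a 4.2-fold higher number from compound 1 to compound 3 (0.62 log units; beyond the scatter)), although the two groups exchanged in that step have the same heavy-atom count, so among these compounds the size of the group at the chain end does not alone set the number. The data offer no measurement that explains why these chain ends differ.

Carbamoylmethyl differs from formyl both in its heavy-atom count and in carrying a hydrogen-bond donor, so this one step cannot separate the two differences, and a dimethylamide at the same place would help to pull them apart. Going by these compounds, how a carboxylic acid or an amine at the end of this chain would read in this assay also remains open, as does whether a shorter or longer chain ending in formyl would keep the number of compound 2.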